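A Second Chloro Group on the Shared Core

The source may hold more compounds than are shown below. What is called first, only, known or untested is meant among the compounds shown, and "the series" means these compounds.

Three benzyl-linked compounds have been tested in a functional assay on HOP-62 cells (Homo sapiens) for cytotoxicity, read by sulforhodamine B assay, with a stated time of 48 h; on this read-out higher numbers stand for weaker inhibition of growth and lower numbers for stronger inhibition of growth. Compound 1 `Nc1nc(Cl)c2ncn(Cc3ccc(CCl)cc3)c2n1` gives 6920 nM, compound 2 `ClCc1ccc(Cn2cnc3c(Cl)nc(Cl)nc32)cc1` gives 2190 nM, and compound 3 `ClCc1ccc(Cn2cnc3ncnc(Cl)c32)cc1` gives 1770 nM. Among the measured compounds shown here, the only measured step between two compounds that differ in a single place, a 3.2-fold lower number from compound 1 to compound 2 (0.50 log units; beyond the scatter), came from a chloro in place of amino on an aromatic carbon. Compound 3 carries the lowest number of the three; its gap to compound 2 lies within the scatter, so no order can be claimed between those two, while its gap to compound 1 lies beyond it.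

Compound 4 `ClCc1ccc(Cn2cnc3nc(Cl)nc(Cl)c32)cc1` has not been measured yet. It differs from compound 3 by chloro in place of hydrogen on an aromatic carbon. For the measured compounds named here, no measured step matches this change: the step from compound 1 to compound 2 swapped one group for another rather than placing a chloro where a hydrogen stood, so it bears on compound 4 only loosely. The values of compound 2 and compound 3, both carrying chloro on the shared core, sit close together, which gives no sign that one more chloro would move the number far. The step from compound 3 to compound 4 is therefore expected to be small, a 1.2-fold lower number from compound 3 to compound 4 (0.07 log units; within the scatter). Compound 4 is estimated at 1500 nM, with a range from 600 nM to 4000 nM.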

Compound 4, concentration for 50% growth inhibition: 1900 nM
Beside the measured number, compound 4's estimate is 1.3-fold (0.10 log units) below it; measured number inside the range.
By their numbers in this assay, from the lowest: compounds 3, 4 and 2 (each within the scatter of the next); then compound 1.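

In this assay, a chloro in place of hydrogen on an aromatic carbon between two ring nitrogen atoms gives only a small step (a 1.1-fold higher number from compound 3 to compound 4 (0.03 log units; within the scatter)), so this position can carry a chloro with no change in growth inhibition that stands out from the scatter. Among the compounds shown here, the earlier compounds could not show this, since their one step was a chloro in place of amino on an aromatic carbon (a 3.2-fold lower number from compound 1 to compound 2 (0.50 log units; beyond the scatter)), a swap of one group for another that lay beyond the scatter. Nothing measured here explains why the number stays level after the chloro enters.

A methoxy group or a carboxylic acid on this same carbon remains untested among the compounds shown, so it is open whether this position would stay as indifferent to groups other than hydrogen and chloro. Going by these compounds, it is also open whether the same small step between these two structures would appear in cell lines other than the one used here.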